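A few compounds are considered here, and "the series" means these few. Any claim that something is new, unique, unknown or untested is made for them only; others in the source may bear on it.

Compound 2, `CCCC(=O)NCCCc1cccc2oc(CCCCc3ccccc3)cc12`, carries a 3-((propylcarbonyl)amino)propyl chain on the shared core. In an assay on NIH3T3 cells for binding affinity to melatonin receptor type 1B (Homo sapiens) (on this read-out lower numbers stand for stronger inhibition and higher numbers for weaker inhibition), compound 2 gives 82 nM, the lowest of the two numbers recorded so far. Compound 1, `CCNC(=O)NC[C@@H]1C[C@H]1c1cccc2oc(CCCCc3ccccc3)cc12`, which presents its amide on a cyclopropyl linker instead of a chain, gives 90 nM in this assay, and the two values lie within the scatter of each other, so no order can be read between them.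

Compound 3, `CC(=O)N[C@H]1CCN(c2cccc3oc(CCCCc4ccccc4)cc23)C1`, has not yet been measured. It differs from compound 2 in one place: 3-acetamidopyrrolidin-1-yl in place of 3-((propylcarbonyl)amino)propyl on an aromatic carbon. The open chain becomes a five-membered ring, and the acetamide replaces the butanamide. Since both measured compounds sit close together, the step from compound 2 to compound 3 is expected to be modest, a 1.5-fold higher number from compound 2 to compound 3 (0.17 log units; within the scatter), a shift that stays within the scatter or slightly towards weaker binding. Compound 3 is therefore estimated at 120 nM, with a plausible range from 30 nM to 500 nM.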

Compound 3, inhibition constant: 14 nM
For compound 3 the middle estimate is 8.6-fold (0.93 log units) above the measured one, outside the stated range (below it).
By their numbers in this assay, from the lowest: compound 3; then compounds 2 and 1 (each within the scatter of the next).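

In this assay, this aromatic carbon of the shared core proves sensitive to the group it carries: 3-acetamidopyrrolidin-1-yl in place of 3-((propylcarbonyl)amino)propyl brings a 5.9-fold lower number from compound 2 to compound 3 (0.77 log units; beyond the scatter). For the compounds shown here, the single step joins several changes, as the open chain gives way to a five-membered non-aromatic ring, the butanamide gives way to an acetamide, and a defined stereocentre enters, so the gain cannot be assigned to any one of them. Nothing available accounts for the gain. As far as these compounds go, it remains open whether a butanamide on the same pyrrolidine ring would give a similar number, and thus whether the ring alone carries the gain. Also open, from the compounds shown here alone, are how the opposite configuration at the stereocentre would read and whether a six-membered piperidine ring would serve as well.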